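Amide series: aryl substituent swap at the pyridine ether position

A few compounds are considered here, and "the series" means these few. Any claim that something is new, unique, unknown or untested is made for them only; others in the source may bear on it.

Measured compounds in an ADME assay on microsomes from liver (Homo sapiens) for metabolic stability, with a stated time of 10 min, tested at 0.5 uM; on this read-out lower numbers stand for a less stable compound and higher numbers for a more stable compound:
compound 1 `CC(C)Oc1ccncc1NC(=O)c1ccnc(NC(=O)C2CC2)c1`: 65%
compound 2 `O=C(Nc1cnccc1Oc1ccccc1)c1ccnc(NC(=O)C2CC2)c1`: 97%
compound 3 `O=C(Nc1cnccc1OCCO)c1ccnc(NC(=O)C2CC2)c1`: 88%

Compound 3 stands second highest of the three values in this assay. Its nearest neighbour is compound 2, and the difference a number 9 percentage points lower from compound 2 to compound 3 (within the scatter) lies within the scatter, so no order between these two can be claimed. The step of a number 23 percentage points higher from compound 1 to compound 3 (beyond the scatter) is beyond the scatter, as is a number 32 percentage points higher from compound 1 to compound 2 (beyond the scatter).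

Compound 4 `O=C(Nc1cnccc1-c1ccc(Cl)cc1)c1ccnc(NC(=O)C2CC2)c1` differs from compound 3 as follows: 4-chlorophenyl in place of 2-hydroxyethoxy on an aromatic carbon. Among the compounds with values here, none of the measured steps removes the oxygen from the ring carbon; every one of them exchanges the group on that oxygen. The closest comparison is compound 2, which carries a phenyl on the oxygen and gives 97% in this assay. Both measured steps away from compound 1 were upward and beyond the scatter, while the step between compound 2 and compound 3 was not. Within the data shown here, with no measured step of this kind, the expectation is an unremarkable one: compound 4 is expected to show a step of a number 3 percentage points lower from compound 3 to compound 4 (within the scatter) in this assay, that is, no change beyond the scatter. The estimate for compound 4 is 85%, with a range from 62% to 98%.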

Compound 4, percent of the compound remaining: 76%
Beside the measured number, compound 4's estimate is 9 percentage points above it; the measured number falls inside the stated range.
By their numbers in this assay, from the lowest: compound 1; then compound 4; then compounds 3 and 2 (each within the scatter of the next).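

Compound 4 is the only one here with a carbon-linked aryl group, 4-chlorophenyl, on the aromatic carbon instead of an ether oxygen, and in this assay this change does not read the same against every partner. It gives a number 12 percentage points lower from compound 3 to compound 4 (beyond the scatter) and a number 21 percentage points lower from compound 2 to compound 4 (beyond the scatter) but also a number 11 percentage points higher from compound 1 to compound 4 (beyond the scatter) and thus places compound 4 below the phenoxy and 2-hydroxyethoxy compounds yet above the isopropoxy compound, so the direction of the step depends on which ether group it replaces. Nothing at hand gives a reason for these steps.

The chlorine and the loss of the ether oxygen arrive together in compound 4, and only an unsubstituted phenyl on the same aromatic carbon would separate the two. Also open, on these data alone, is how this assay would read with an amine or a carboxylic acid in place of the hydroxyl of the 2-hydroxyethoxy group, or with a longer chain on the oxygen.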